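The compounds below may be only part of what the source reports. "The series", "measured", "known", "first", "only" and "open" are said of these compounds alone.

Working notes on the series. Compound 1 `COc1cc(N(CC2CC2)c2ccc(Cl)c3ccccc23)cnc1C(=O)[C@H]1C[C@@H]1C(=O)O`, compound 2 `COc1cc(N(CC2CC2)c2ccccc2)cnc1C(=O)[C@H]1C[C@@H]1C(=O)O` and compound 3 `COc1cc(N(CC2CC2)c2cccc(C(F)(F)F)c2)cnc1C(=O)[C@H]1C[C@@H]1C(=O)O` share one core and have been run in an ADME assay on cells (Hepatocyte, Homo sapiens) for metabolic stability, read by LC-MS, with a stated time of 60 min, tested at 1 uM; on this read-out lower numbers stand for slow clearance and higher numbers for fast clearance. In this assay compound 1 gives 5 uL/min, compound 2 gives 3 uL/min and compound 3 gives 2.3 uL/min. Compound 3 carries the lowest number of the three: the gap to compound 2 is within the scatter, the gap to compound 1 is beyond it. Among the measured compounds shown here, the one single-point step measured, a 1.3-fold lower number from compound 2 to compound 3 (0.12 log units; within the scatter), changes an aromatic substituent only.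

Compound 4 `CCCN(c1cccc(C(F)(F)F)c1)c1cnc(C(=O)[C@H]2C[C@@H]2C(=O)O)c(OC)c1` differs from compound 3 by ethyl in place of cyclopropyl on a saturated chain carbon bound to a nitrogen on an aromatic ring. For the measured compounds named here, no measured step touches this chain, so nothing in the numbers points to a change beyond the scatter, and the expected step is a 1.3-fold higher number from compound 3 to compound 4 (0.12 log units; within the scatter). Compound 4 is therefore estimated at 3 uL/min, with a range from 1.5 uL/min to 6 uL/min, pending measurement.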

Compound 4, intrinsic clearance in a liver preparation (reported as CLH), per the amount of preparation that the assay uses: 7.2 uL/min
Compound 4: the middle estimate sits 2.4-fold (0.38 log units) below what was measured; the whole stated range lies below it.
By their numbers in this assay, from the lowest: compounds 3, 2, 1 and 4 (each within the scatter of the next, the first and the last beyond it).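

In this assay this position proves sensitive: with ethyl in place of cyclopropyl on a saturated chain carbon bound to a nitrogen on an aromatic ring, the series shows a 3.1-fold higher number from compound 3 to compound 4 (0.50 log units; beyond the scatter). Among the compounds shown here, this is the first measured step at this chain, and unlike the aromatic substituent step, it lies beyond the scatter. No available evidence bears on what lies behind the change. Open, on these data alone, is whether a longer chain, a methyl or a cyclobutyl at this place would give a similar number. Also open, as far as these compounds go, is whether the step holds with the aromatic groups of compound 1 and compound 2.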